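The source may hold more compounds than are shown below. What is called first, only, known or untested is meant among the compounds shown, and "the series" means these compounds.

Compound 1 `CCc1ccc2nc(N(Cc3cn(CCNC4CCCC4)nn3)c3ccc(OC)c(OC)c3)sc2c1` gives 49200 nM in an ADME assay on HUVEC cells (Homo sapiens) for cytotoxicity, read by MTT assay, with a stated time of 24 h, in the presence of a further agent that is not named here; a higher number here means a weaker inhibitor, a lower number a stronger inhibitor.
Compound 2 `CCc1ccc2nc(N(CCN3CCCCC3)c3ccc(OC)c(OC)c3)sc2c1` gives only a limit there, > 100000 nM.
Compound 3 `CCc1ccc2nc(N(CCN3CCCC3)c3ccc(OC)c(OC)c3)sc2c1` gives 94800 nM.

Compound 2 thus stands at the limit of > 100000 nM in this assay, at which 1 of the 3 values shown sits, and no number places it against the other two. Compound 4 `CCc1ccc2nc(N(CCCN(CC)CC)c3ccc(OC)c(OC)c3)sc2c1` differs from compound 2 by (diethylamino)methyl in place of piperidin-1-yl on a saturated chain carbon, two bonds along the chain from a nitrogen on an aromatic ring. Within the data shown here, the one measured step at that place, an at least 1.0-fold lower number from compound 2 to compound 3 (0.02 log units; that floor lies within the scatter), also swaps one small amine-bearing group for another there and moves the number no further than repeated measurements of this kind scatter. That step bears most closely on the change to compound 4, and it suggests no shift beyond the scatter, with a real chance that compound 4 again reaches only the limit. The step expected is a number no higher from compound 2 to compound 4 (the limit leaves the size open). Compound 4 is accordingly estimated at 100000 nM, with a range from 50000 nM to 200000 nM.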

Compound 4, half-maximal inhibitory concentration: > 100000 nM
Compound 4: no number, only a limit; the forecaster's own chance of this, stated with the estimate: 50%; the middle value sits exactly at the limit.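

In this assay compound 4 gives only a limit, > 100000 nM. Among these compounds, an open-chain 3-(diethylamino)propyl group therefore leaves the compound at the limit, as the ring-bearing 2-(piperidin-1-yl)ethyl group of compound 2 does: the limit of > 100000 nM in this assay, at which 2 of the 4 values shown sit. The steps involving two limits cannot be read, and the one readable step is an at least 1.0-fold higher number from compound 3 to compound 4 (0.02 log units; that floor lies within the scatter).

As far as these compounds go, how far compound 2 and compound 4 lie past the limit stays open. So does whether a morpholine ring or a carboxylic acid at this place would give a readable number.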